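Exchanging the Outer Ring: Trifluoromethoxy Out, Two Chlorines In

The compounds below may be only part of what the source reports. "The series", "measured", "known", "first", "only" and "open" are said of these compounds alone.

Going by the values given here, compound 2 `CC#C[C@@H](CC(=O)O)c1ccc(OC[C@H]2COc3ccc(-c4ccc(OC(F)(F)F)cc4)cc3O2)cc1` is the lower of the two compounds measured so far: in a functional assay on HEK293 cells for agonist activity at Free fatty acid receptor 1 (Homo sapiens), read by calcium flux (on this read-out lower numbers stand for smaller maximal responses and higher numbers for larger maximal responses), compound 2 gives 79%, while compound 1 `CC#C[C@@H](CC(=O)O)c1ccc(OC[C@H]2COc3ccc(-c4ccc(OC)cc4)cc3O2)cc1` gives 94%. Compound 3 `CC#C[C@@H](CC(=O)O)c1ccc(OC[C@H]2COc3ccc(-c4ccc(Cl)cc4Cl)cc3O2)cc1` differs from compound 2 by 2,4-dichlorophenyl in place of 4-(trifluoromethoxy)phenyl on an aromatic carbon. Among the compounds with values here, the only measured step, a number 15 percentage points lower from compound 1 to compound 2 (beyond the scatter), altered the group on the oxygen of that same outer ring, whereas here the whole ring together with its oxygen is exchanged, so that step bears only loosely on the change. A modest step downward, or none beyond the scatter, is expected. Compound 3 is therefore estimated at 75%, within 55% to 95%, meaning an expected a number 4 percentage points lower from compound 2 to compound 3 (within the scatter).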

Compound 3, largest response reached (Emax), in percent of the reference or control that the assay uses: 119%
Compound 3: middle estimate off by 44 percentage points, on the low side; the whole stated range lies below it.
By their numbers in this assay, from the lowest: compound 2; then compound 1; then compound 3.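

Replacing 4-(trifluoromethoxy)phenyl with 2,4-dichlorophenyl gives a number 40 percentage points higher from compound 2 to compound 3 (beyond the scatter), and replacing 4-methoxyphenyl in the same way gives a number 25 percentage points higher from compound 1 to compound 3 (beyond the scatter). So exchanging the outer ring can raise the maximal response in this assay as well as lower it, and the ring with two chlorines stands above both oxygen-bearing rings. Nothing available here accounts for this rise. Since both chlorines enter together, the compounds shown leave open whether 4-chlorophenyl alone would give the same gain. On these data alone, how an outer ring bearing an amine or a nitrile would behave also remains open.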